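This account rests on a few compounds, and the source may have more. Where it says the series, first, only, none or still open, it means among the compounds named here.

Measured compounds:
compound 1, `Cn1nc(Cc2nnc(SCCCCCCCC(=O)Nc3ccc(Cl)cc3Cl)n2CCCO[Si](C)(C)C(C)(C)C)c2ccccc2c1=O` — in an assay on 32D cells for inhibition of interleukin-15 (Mus musculus), read by resazurin assay, with stated times of 30 min and 2.5 days, in the presence of a further agent that is not named here (a lower number here means a stronger inhibitor, a higher number a weaker inhibitor), compound 1 reaches only the assay limit, > 30000 nM.
compound 2, `Cn1c(Cc2nn(CCC=O)c(=O)c3ccccc23)nnc1SCC(=O)Nc1ccc(Cl)cc1Cl` — in this assay compound 2 gives 30000 nM.

For the measured compounds named here, compound 2 holds the only actual number; the other entry, that of compound 1, is a limit rather than a number, as noted by the limit of > 30000 nM in this assay, at which 1 of the 2 values shown sits. Going by the values given here, both results sit at the weak end of what this assay resolves, so no step between measured compounds can be read.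

Compound 3, `CN(C)CCCn1nc(Cc2nnc(SCC(=O)Nc3ccc(Cl)cc3Cl)n2C)c2ccccc2c1=O`, differs from compound 2 by (dimethylamino)methyl in place of formyl on a saturated chain carbon, two bonds along the chain from an aromatic nitrogen, in words (dimethylamino)methyl in place of formyl on a saturated chain carbon, two bonds along the chain from an aromatic nitrogen. Among the compounds with values here, with no measured step to lean on, the expectation for this change is no shift beyond the usual scatter, in either direction. The step from compound 2 is thus expected to be a 1.2-fold lower number from compound 2 to compound 3 (0.08 log units; within the scatter). Compound 3 is accordingly estimated at 25000 nM, with a range from 8000 nM to 60000 nM, and a fair chance that only a limit is reported.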

Compound 3, half-maximal inhibitory concentration: 16700 nM
Compound 3: middle estimate off by 1.5-fold (0.18 log units), on the high side; low and high end bracket the measured number.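

For the compounds shown here, compound 3 supplies the first readable step: in this assay, (dimethylamino)methyl in place of formyl on a saturated chain carbon, two bonds along the chain from an aromatic nitrogen, gives a 1.8-fold lower number from compound 2 to compound 3 (0.25 log units; within the scatter). This position therefore carries either 2-formylethyl or 3-(dimethylamino)propyl with no difference beyond the scatter, so this one exchange does not separate the two compounds. Compound 1 remains an entry at a limit, not a number: the limit of > 30000 nM in this assay, at which 1 of the 3 values shown sits.

On these data alone, whether a carboxylic acid, a morpholine or a longer chain ending in an amine at this position would give a step beyond the scatter remains open. Also open, as far as these compounds go, is whether any change elsewhere on the shared core, such as on the dichlorophenyl amide, would move the number further.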